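A few compounds are considered here, and "the series" means these few. Any claim that something is new, unique, unknown or untested is made for them only; others in the source may bear on it.

Working notes on the acylhydrazone series.

Compound 2 `O=C(N/N=C/c1ccc2c(c1)no[n+]2[O-])c1ccc(I)cc1` carries iodo on the benzoyl ring. In an ADME assay on cells (Fibroblast, Homo sapiens) for inhibition, read by MTT assay, with a stated time of 24 h (a lower number here means a stronger inhibitor, a higher number a weaker inhibitor), compound 2 gives > 200000 nM, which is a limit of the assay and not a number. Compound 1 `CCCCOc1ccc(C(=O)N/N=C/c2ccc3c(c2)no[n+]3[O-])cc1` carries butoxy instead. In this assay compound 1 gives > 200000 nM, likewise a limit. The step that the two limits leave unreadable from compound 1 to compound 2 is thus not readable, because both values sit at the limit of > 200000 nM in this assay, at which 2 of the 3 values shown sit. Among the measured compounds shown here, compound 3 `O=C(N/N=C/c1ccc2c(c1)no[n+]2[O-])c1ccc(Cl)cc1Cl`, with two chloro groups, is the only member with a number: in this assay compound 3 gives 38300 nM.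

Compound 4 `CCCCc1ccc(C(=O)N/N=C/c2ccc3c(c2)no[n+]3[O-])cc1` is not yet measured. The change from compound 2 is butyl in place of iodo on an aromatic carbon. For the measured compounds named here, the only measured step bearing on this exchange of groups on that aromatic carbon is the one from compound 1 to compound 2, and it gives no size. No step beyond the scatter can be expected in either direction for this assay; the estimate for compound 4 is 250000 nM, with a range of 60000 nM to 1000000 nM. The step that the limit leaves unreadable from compound 2 to compound 4 this estimate means is expected to remain unreadable, as compound 4 is expected to sit at the same limit.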

Compound 4, half-maximal inhibitory concentration: > 200000 nM
Compound 4: no number, only a limit; the forecaster's own chance of this, stated with the estimate: 70%; the middle value does not contradict the limit.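

Compound 1, compound 2 and compound 4 all stand at a limit of the assay and not at a number, so no step among them can be read in this assay: the limit of > 200000 nM in this assay, at which 3 of the 4 values shown sit.

The compounds shown leave open whether butoxy, iodo and butyl differ at all in this assay.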